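Compound 3 against the cytotoxicity limit

A few compounds are considered here, and "the series" means these few. Any claim that something is new, unique, unknown or untested is made for them only; others in the source may bear on it.

Measured in an ADME assay on WI-38 cells (Homo sapiens) for cytotoxicity, read by MTT assay, with a stated time of 96 h; on this read-out lower numbers stand for stronger inhibition and higher numbers for weaker inhibition:
- compound 1 `O=[N+]([O-])c1ccc(C2=NOC(c3ccc(N4CCN(Cc5ccc(F)nc5)CC4)cc3)C2)o1`: > 50000 nM
- compound 2 `O=[N+]([O-])c1ccc(C2=NOC(c3ccc(-c4ccncc4)cc3)C2)o1`: > 50000 nM

Compound 1 stands at a limit of the assay, > 50000 nM, not at a number. The two measured compounds share (the limit of > 50000 nM in this assay, at which 2 of the 2 values shown sit). Compound 3 `CC(C)(C)OC(=O)N1CCN(c2ccc(C3CC(c4ccc([N+](=O)[O-])o4)=NO3)cc2)CC1` carries tert-butoxycarbonyl in place of (6-fluoropyridin-3-yl)methyl on an amine nitrogen in a ring. For the measured compounds named here, no measured step in this assay gauges such a change, and both compounds measured so far give only limits. No step beyond the scatter is expected, and any departure would be expected toward stronger inhibition. The expected change is a number no higher from compound 1 to compound 3 (the limit leaves the size open). Compound 3 is estimated at 50000 nM, within 20000 nM to 100000 nM.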

Compound 3, half-maximal inhibitory concentration: > 50000 nM
Compound 3: no number, only a limit (the forecaster's own chance of this, stated with the estimate: 75%); the middle value lies on the limit itself.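

No step from compound 1 to compound 3 can be read in this assay, as both values are limits: the limit of > 50000 nM in this assay, at which 3 of the 3 values shown sit.

The compounds shown leave open how tert-butoxycarbonyl and (6-fluoropyridin-3-yl)methyl compare, and whether any change to the shared core gives a number rather than a limit.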